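Swapping a Dichlorophenyl for a Methoxyphenyl

The compounds below may be only part of what the source reports. "The series", "measured", "known", "first", "only" and "open" are said of these compounds alone.

Measured so far:
compound 1 `O=S(=O)(NCCNCc1ccc(-c2ccccc2)cc1)c1cc(C(F)(F)F)cc(C(F)(F)F)c1` gives 2700 nM
compound 2 `O=S(=O)(NCCCNCc1ccc(Cl)c(Cl)c1)c1cc(C(F)(F)F)cc(C(F)(F)F)c1` gives 2900 nM

In a functional assay on BE(2)-C cells (Homo sapiens) for inhibition, read by MTT assay, with a stated time of 72 h (on this read-out higher numbers stand for weaker inhibition of growth and lower numbers for stronger inhibition of growth), compound 2 gives 2900 nM, and compound 1 gives 2700 nM; the two numbers lie within the usual scatter of each other, so neither stands apart. Compound 3 `COc1cccc(CNCCCNS(=O)(=O)c2cc(C(F)(F)F)cc(C(F)(F)F)c2)c1` has not been measured. It differs from compound 2 in one place: 3-methoxyphenyl in place of 3,4-dichlorophenyl on a saturated chain carbon bound to an amine nitrogen. For the measured compounds named here, no measured pair shows this change, so the direction and size of the step rest on expectation alone. Compound 3 is estimated at 4500 nM, within 1500 nM to 14000 nM, the step of a 1.6-fold higher number from compound 2 to compound 3 (0.19 log units; within the scatter) expected to be small, at most modestly toward weaker inhibition.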

Compound 3, concentration for 50% growth inhibition: 4500 nM
Beside the measured number, compound 3's estimate shows no gap at the digits printed, and the stated range covers the measured number.
By their numbers in this assay, from the lowest: compounds 1, 2 and 3 (each within the scatter of the next).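

In this assay, placing 3-methoxyphenyl where 3,4-dichlorophenyl stood, on a saturated chain carbon bound to an amine nitrogen, gives a 1.6-fold higher number from compound 2 to compound 3 (0.19 log units; within the scatter) and so leaves the two compounds indistinguishable. For the compounds shown here, this is the first one-place comparison, and it shows that this position accepts a ring with two chlorine atoms or one with a methoxy group without a step beyond the scatter. No measurement on hand offers an explanation for this result.

On these data alone, whether a nitrile or a carboxylic acid on this ring would give a clearer step remains open. So does the effect of a longer chain.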